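Replacing a Thiophene Arm with a Difluoroethylphenyl Group

The source may report more compounds than this note shows. Statements on the series, on what has been measured and on what is new or still open speak of the compounds shown alone.

Three compounds share one core. Compound 1 `O=C(C[C@H](CCN1CCCCC1)NC(=O)c1cc(-c2ccccn2)n(C2CCCC2)n1)NC1CCC1` and compound 2 `O=C(C[C@H](CCN1CCCCC1)NC(=O)c1cc(-c2cccs2)n(C2CCCC2)n1)NC1CCC1` carry five-membered aromatic arms, while compound 3 `COc1cccc(F)c1-c1cc(C(=O)N[C@@H](CCN2CCCCC2)CC(=O)NC2CCC2)nn1C1CCCC1` carries a substituted phenyl arm. In an ADME assay on microsomes from liver (Rattus norvegicus, strain Sprague-Dawley) for metabolic stability, read by LC-MS, using NADPH, with a stated time of 30 min, tested at 1 uM (on this read-out higher numbers stand for a more stable compound and lower numbers for a less stable compound), compound 3 gives 74.3%. In this assay compound 2 has no reported number ("nd" (no result reported)), and compound 1 likewise ("nd" (no result reported)), so compound 2 stands without a value to compare. Compound 4 `CC(F)(F)c1ccccc1-c1cc(C(=O)N[C@@H](CCN2CCCCC2)CC(=O)NC2CCC2)nn1C1CCCC1` differs from compound 2 by 2-(1,1-difluoroethyl)phenyl in place of thiophen-2-yl on an aromatic carbon. With no number for compound 2 in this assay, no direction or size of step can be stated; the expectation rests on compound 3 alone. Compound 4 is therefore estimated in this assay at 65%, with a range from 40% to 90%.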

Compound 4, percent of the compound remaining: 77.1%
The estimate for compound 4 lay 12.1 percentage points below the measured number; low and high end bracket the measured number.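

In this assay, within the data shown here, the one readable step at this position is a number 2.8 percentage points higher from compound 3 to compound 4 (within the scatter) and so, on this read-out, 2-(1,1-difluoroethyl)phenyl and 2-fluoro-6-methoxyphenyl cannot be told apart. Steps from compound 1 and compound 2 cannot be read, as neither compound has a number. No measurement shown here offers an explanation for this result. The compounds shown leave open how a plain phenyl or a trifluoromethylphenyl arm would read on this aromatic carbon, and whether the same holds with cyclohexyl in place of cyclopentyl.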